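Chloro for Cyano on a Weak Phenyl Imidazoline

The source may hold more compounds than are shown below. What is called first, only, known or untested is meant among the compounds shown, and "the series" means these compounds.

Compound 1 `NC(=O)c1ccccc1C1Cc2nccn2C1` has "not determined" (no result reported) in a functional assay on CHO cells for agonist activity at Alpha-1B adrenergic receptor (Homo sapiens), read by FLIPR and calcium flux; on this read-out lower numbers stand for an effect already at smaller amounts and higher numbers for an effect only at larger amounts of compound. Compound 2 `N#Cc1ccccc1C1Cc2nccn2C1` gives only a limit in this assay, namely > 10000 nM. Compound 2 thus sits at the ceiling of what was measured, as the limit of > 10000 nM in this assay, at which 1 of the 2 values shown sits, shows. Compound 3 `Clc1ccccc1C1Cc2nccn2C1` differs from compound 2 by chloro in place of cyano on an aromatic carbon. Among the compounds with values here, no measured step covers this change, so any expectation for compound 3 rests on compound 2 and its limit > 10000 nM. Compound 3 is expected to stay near that limit, with the step of a number no higher from compound 2 to compound 3 (the limit leaves the size open) expected to lie within the scatter. The estimate for compound 3 is 10000 nM, in a range from 3000 nM to 30000 nM.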

Compound 3, half-maximal effective concentration: 1100 nM
Compound 3: middle estimate off by 9.1-fold (0.96 log units), on the high side, outside the stated range (below it).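

Placing chloro instead of cyano on this aromatic carbon gives a measurable effect in this assay, with an at least 9.0-fold lower number from compound 2 to compound 3 (0.95 log units; beyond the scatter). This shows that the read-out at this position depends on the group it carries, which compound 2 alone could not show. The entry for compound 2 is a limit of the assay and not a number: the limit of > 10000 nM in this assay, at which 1 of the 3 values shown sits.

As far as these compounds go, it remains open how other groups at this position, such as methoxy or an amine, would compare with chloro. Also open, from the compounds shown here alone, is how compound 1, with its amide, would compare, since it has no reported result.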